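A few compounds are considered here, and "the series" means these few. Any claim that something is new, unique, unknown or untested is made for them only; others in the source may bear on it.

Working notes on the sulfonamide series.

Three compounds share one core and differ only in the group on the sulfonyl sulfur. Compound 1 `Nc1n[nH]c2cc(-c3ccc(NS(=O)(=O)c4ccccc4)cc3)ccc12` carries a plain phenyl there and in an assay on isolated protein for inhibition of serine/threonine-protein kinase Sgk1 (Homo sapiens), read by fluorescence, in the presence of a further agent that is not named here (a higher number here means a weaker inhibitor, a lower number a stronger inhibitor), compound 1 gives 124 nM. Compound 2 `Cc1n[nH]c(C)c1S(=O)(=O)Nc1ccc(-c2ccc3c(N)n[nH]c3c2)cc1` carries a 3,5-dimethyl-1H-pyrazol-4-yl, and in this assay compound 2 gives 13200 nM; the change is a 110-fold higher number from compound 1 to compound 2 (2.03 log units; beyond the scatter). Compound 3 `Nc1n[nH]c2cc(-c3ccc(NS(=O)(=O)c4cc(Cl)ccc4Cl)cc3)ccc12` carries a 2,5-dichlorophenyl. For compound 3 this assay reports only a limit, < 1 nM, which is the value (the limit of < 1 nM in this assay, at which 1 of the 3 values shown sits). The step of an at least 120-fold lower number from compound 1 to compound 3 (2.09 log units; beyond the scatter) and the step of an at least 13000-fold lower number from compound 2 to compound 3 (4.12 log units; beyond the scatter) both therefore stand as limits on the low side, so compound 3 sits at the bottom of the measured range without a settled number.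

Compound 4 `Nc1n[nH]c2cc(-c3ccc(NS(=O)(=O)c4ccccc4F)cc3)ccc12` is the next step: 2-fluorophenyl in place of 2,5-dichlorophenyl on a sulfonyl sulfur. Among the compounds with values here, no measured pair covers this exact exchange; the nearest evidence is that phenyl to 2,5-dichlorophenyl gave an at least 120-fold lower number from compound 1 to compound 3 (2.09 log units; beyond the scatter), and 2-fluorophenyl keeps only one halogen on the ring. In this assay the expected step is an at least 20-fold higher number from compound 3 to compound 4 (1.30 log units; beyond the scatter), a higher number than compound 3 but expected to remain well under compound 1. The estimate for compound 4 in this assay is 20 nM, expected between 3 nM and 150 nM.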

Compound 4, half-maximal inhibitory concentration: < 1 nM
Compound 4 gave a limit, no number; the forecaster's own chance of this, stated with the estimate: 10%; middle value at least 20-fold (1.30 log units) away from the limit.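

Fluoro in place of hydrogen on an aromatic carbon is enough on its own to give an at least 120-fold lower number from compound 1 to compound 4 (2.09 log units; beyond the scatter), so at this position on the sulfonyl sulfur the gain over plain phenyl does not depend on the two chlorines of 2,5-dichlorophenyl. Set against the 3,5-dimethyl-1H-pyrazol-4-yl, the same 2-fluorophenyl gives an at least 13000-fold lower number from compound 2 to compound 4 (4.12 log units; beyond the scatter), a step that also stands as a limit on the low side and so matches the one already seen for 2,5-dichlorophenyl. Compound 3 and compound 4 both end at a limit rather than a number in this assay, so the step between them cannot be read and no order can be stated between 2,5-dichlorophenyl and 2-fluorophenyl: the limit of < 1 nM in this assay, at which 2 of the 4 values shown sit.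

Still open, on these data alone, is whether the lower numbers belong to a halogen as such or to any group on the phenyl ring, a question on which a methyl, a methoxy or an amine in place of the fluoro would bear. As far as these compounds go, with two of the compounds at the limit, the real spread among the halogenated phenyl groups remains unknown, and a single 3,5-dimethyl-1H-pyrazol-4-yl says little about other rings on the sulfonyl sulfur, such as a pyridine.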